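The source may hold more compounds than are shown below. What is called first, only, known or untested is meant among the compounds shown, and "the series" means these compounds.

Measured so far:
- compound 1 `COc1ncnc2c1c(I)cn2[C@@H]1O[C@H](CO)[C@@H](O)[C@H]1O`: in a functional assay on HCT-116 cells (Homo sapiens), read by MTT assay, with a stated time of 72 h (a lower number here means a stronger inhibitor, a higher number a weaker inhibitor), compound 1 gives only the limit > 20000 nM.
- compound 2 `COc1ncnc2c1c(-c1ccco1)cn2[C@@H]1O[C@H](CO)[C@@H](O)[C@H]1O`: in this assay compound 2 gives 40 nM.

For the measured compounds named here, compound 2 is the only compound with a number in this assay; the other value shown is a limit (the limit of > 20000 nM in this assay, at which 1 of the 2 values shown sits). Going by the values given here, the single measured step, an at least 500-fold lower number from compound 1 to compound 2 (2.69 log units; beyond the scatter), shows that replacing iodo on an aromatic carbon by a five-membered aromatic ring matters greatly here.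

Compound 3 `COc1ncnc2c1c(-c1ccsc1)cn2[C@@H]1O[C@H](CO)[C@@H](O)[C@H]1O` differs from compound 2 by thiophen-3-yl in place of furan-2-yl on an aromatic carbon. Among the compounds with values here, no measured step compares two heteroaryl groups of this kind at this position, so the large step from compound 1 to compound 2 bears only loosely: it says a five-membered aromatic ring at this carbon is tolerated, not which one. The exchange leaves size and ring count unchanged, so the step of a 1.4-fold higher number from compound 2 to compound 3 (0.14 log units; within the scatter) is expected to stay within the scatter. Compound 3 is therefore estimated at 55 nM, with a range from 20 nM to 160 nM.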

Compound 3, half-maximal inhibitory concentration: 140 nM
Estimate against measurement, compound 3: 2.5-fold (0.41 log units) below; low and high end bracket the measured number.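

In this assay the two five-membered aromatic rings are not interchangeable on this aromatic carbon, with a 3.5-fold higher number from compound 2 to compound 3 (0.54 log units; beyond the scatter), even though the exchange keeps the heavy-atom count and the ring count. Which ring sits here therefore matters, not only that one is present. Thiophen-3-yl also stands far from iodo, with an at least 140-fold lower number from compound 1 to compound 3 (2.15 log units; beyond the scatter), so the large step away from iodo is not confined to furan-2-yl, though its size remains a bound, since compound 1 gives only a limit: the limit of > 20000 nM in this assay, at which 1 of the 3 values shown sits.

The exchange changes the hetero atom and the point of attachment together, so the compounds shown cannot separate oxygen against sulfur from attachment at the 2-yl against the 3-yl; thiophen-2-yl would address this. From the compounds shown here alone, how phenyl, an amine or a longer alkyl chain on this carbon would read also remains open.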